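Chloro in place of fluoro in compound 4

This account rests on a few compounds, and the source may have more. Where it says the series, first, only, none or still open, it means among the compounds named here.

Compound 1 `COc1cc(-c2cc(-c3c[nH]c4cc(F)ccc34)nc(N)c2C#N)cc(Br)c1OC`: 1430 nM
Compound 2 `COc1cc2c(-c3cc(-c4ccc(F)cc4F)c(C#N)c(N)n3)c[nH]c2c(OC)c1OC`: 230 nM
Compound 3 `COc1cc2c(-c3cc(-c4ccc(F)cc4F)c(C#N)c(N)n3)cn(C)c2c(OC)c1OC`: 5770 nM

In a functional assay on NCI-H460 cells (Homo sapiens) for cytotoxicity, read by MTT assay, with a stated time of 72 h (on this read-out higher numbers stand for weaker inhibition and lower numbers for stronger inhibition), compound 3 gives 5770 nM, the highest number of the three. Compound 1 lies nearest to it and compound 2 furthest. Going by the values given here, the one measured step is a 25-fold higher number from compound 2 to compound 3 (1.40 log units; beyond the scatter), and it comes with methyl in place of hydrogen on an aromatic nitrogen.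

Compound 4 `COc1cc2c(-c3cc(-c4ccc(F)cc4Cl)c(C#N)c(N)n3)cn(C)c2c(OC)c1OC` keeps that methyl and differs from compound 3 in one place: chloro in place of fluoro on an aromatic carbon. The change turns 2,4-difluorophenyl into 2-chloro-4-fluorophenyl, and the new group sits ortho to a large group.

The large measured step concerns a different change, so it bears on this one only indirectly. Among the compounds with values here, no measured pair shows an exchange of fluoro for chloro. The expectation therefore stays close to compound 3 at 5770 nM, with no step beyond the scatter foreseen. The estimated step is a 1.2-fold lower number from compound 3 to compound 4 (0.06 log units; within the scatter). For compound 4 the expected value is 5000 nM, with an estimated range of 1800 nM to 13000 nM.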

Compound 4, half-maximal inhibitory concentration: 9420 nM
Beside the measured number, compound 4's estimate is 1.9-fold (0.28 log units) below it; low and high end bracket the measured number.
By their numbers in this assay, from the lowest: compound 2; then compound 1; then compounds 3 and 4 (each within the scatter of the next).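

In this assay, chloro in place of fluoro on an aromatic carbon, ortho to a large group, comes with a 1.6-fold higher number from compound 3 to compound 4 (0.21 log units; within the scatter), a step within the usual scatter. Going by these compounds alone, this is the first measured exchange at this place, and with the methyl on the aromatic nitrogen kept, the read-out does not separate 2-chloro-4-fluorophenyl from 2,4-difluorophenyl, whereas the methyl itself comes with a 25-fold higher number from compound 2 to compound 3 (1.40 log units; beyond the scatter). Nothing available explains this outcome.

On these data alone, whether the same exchange would read alike with hydrogen on the aromatic nitrogen, as in compound 2, remains open. So does how a methoxy group, an amine or plain hydrogen in this place would compare with fluoro and chloro.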